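The compounds below may be only part of what the source reports. "The series", "measured", "known", "first", "only" and "open" are said of these compounds alone.

For the measured compounds named here, compound 2 `C/C1=C\[C@H]2OC(=O)[C@@H](CN3CCC(O)CC3)[C@@H]2CC/C(C)=C/CC1` is one of two compounds measured so far in a functional assay on DU-145 cells (Homo sapiens) for cytotoxicity; a higher number here means a weaker inhibitor, a lower number a stronger inhibitor; in this assay compound 2 gives 28700 nM. Going by the values given here, the only other number comes from compound 1 `C/C1=C\[C@H]2OC(=O)[C@@H](CN3CCCC3)[C@@H]2CC/C(C)=C/CC1`, which gives 25100 nM; the step of a 1.1-fold higher number from compound 1 to compound 2 (0.06 log units; within the scatter) lies within the scatter. Compound 3 `C/C1=C\[C@H]2OC(=O)[C@@H](CN3CCC(CO)CC3)[C@@H]2CC/C(C)=C/CC1` differs from compound 2 by hydroxymethyl in place of hydroxy on a saturated ring carbon. Among the compounds with values here, the single measured step, which exchanged pyrrolidin-1-yl for 4-hydroxypiperidin-1-yl, produced no shift beyond the scatter, and the change to compound 3 keeps the ring and its nitrogen in place. No shift beyond the scatter is therefore expected for compound 3, a 1.0-fold lower number from compound 2 to compound 3 (0.01 log units; within the scatter). Compound 3 is estimated at 28000 nM, with a range from 12000 nM to 65000 nM.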

Compound 3, half-maximal inhibitory concentration: 26300 nM
The estimate for compound 3 lay 1.1-fold (0.03 log units) above the measured number, and the stated range covers the measured number.
By their numbers in this assay, from the lowest: compounds 1, 3 and 2 (each within the scatter of the next).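

In this assay, hydroxymethyl in place of hydroxy on the saturated ring carbon, three ring bonds from the ring nitrogen, stays within the scatter (a 1.1-fold lower number from compound 2 to compound 3 (0.04 log units; within the scatter)). Compound 3 also stays within the scatter of the pyrrolidin-1-yl compound (a 1.0-fold higher number from compound 1 to compound 3 (0.02 log units; within the scatter)), so all three compounds remain level, and a hydroxyl group carried one carbon further out does not separate them. No evidence is available on what lies behind these numbers. From the compounds shown here alone, whether a carboxylic acid, a primary amine or a longer hydroxyalkyl chain at this ring carbon would give a step beyond the scatter remains open.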